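The compounds below may be only part of what the source reports. "The series", "measured", "known", "first", "only" and "open" are said of these compounds alone.

Measured so far, in a functional assay on MCF7 cells (Homo sapiens) for antiproliferative activity, read by MTT assay, with a stated time of 72 h; on this read-out lower numbers stand for stronger inhibition and higher numbers for weaker inhibition:

Compound 1 `O=C(COc1ccc(C(=O)/C=C/c2ccccc2Br)cc1)N[C@H]1CCOC1=O` gives 15300 nM.
Compound 2 `O=C(CNc1ccccc1Cl)N[C@H]1CCOC1=O` reaches only a limit of this assay, > 64000 nM.
Compound 3 `Cc1cc(Cl)ccc1NCC(=O)N[C@H]1CCOC1=O` likewise reaches only a limit of this assay, > 64000 nM.

Among the measured compounds shown here, compound 1 is therefore the only compound in the set with a number; the other two values sit at the limit of > 64000 nM in this assay, at which 2 of the 3 values shown sit, and no ordering among the three beyond that can be drawn. For the measured compounds named here, no pair of measured compounds differs in a single place, so no measured step is available.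

Compound 4 `O=C(COc1ccc(C(=O)/C=C/c2cccc(Cl)c2)cc1)N[C@H]1CCOC1=O` is not yet measured. It shares the core of compound 1 and differs from it in one place: 3-chlorophenyl in place of 2-bromophenyl on a double-bonded chain carbon bound to a double-bonded chain carbon. Going by the values given here, with no measured step to lean on and only compound 1 as an anchor, the step from compound 1 to compound 4 is expected to be small, a 1.0-fold lower number from compound 1 to compound 4 (0.01 log units; within the scatter), in no particular direction and not beyond the scatter of this assay. Compound 4 is thus estimated at 15000 nM, in a range from 5000 nM to 45000 nM.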

Compound 4, half-maximal inhibitory concentration: 20900 nM
For compound 4 the middle estimate is 1.4-fold (0.14 log units) below the measured one; the range from low to high includes it.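

In this assay, the exchange of 2-bromophenyl for 3-chlorophenyl on a double-bonded chain carbon bound to a double-bonded chain carbon gives a 1.4-fold higher number from compound 1 to compound 4 (0.14 log units; within the scatter). Among the compounds shown here, this is the first step that can be read, and it shows that this change, which alters both the halogen and its place on the ring, leaves the number within the scatter, so compound 1 and compound 4 cannot be ordered. No measured property bears on this step.

For the compounds shown here, compound 2 and compound 3 each stand at a limit rather than a number and differ from compound 1 in more than one place, so they add no step here: the limit of > 64000 nM in this assay, at which 2 of the 4 values shown sit. Whether a phenyl carrying an amine or a carboxylic acid at this place would move the number beyond the scatter stays open.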